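Piperazine amide series: metabolic stability, step to compound 4

The compounds below may be only part of what the source reports. "The series", "measured", "known", "first", "only" and "open" are said of these compounds alone.

Measured so far:
compound 1 `COc1cc(C)c(S(=O)(=O)N(C)CCOCC(=O)N2CCC(C(C)(C)CN(C)C)CC2)c(C)c1` — 36%
compound 2 `COc1cc(C)c(S(=O)(=O)N(C)CCOCC(=O)N2CCN([C@@H]3CN4CCC3CC4)CC2)c(C)c1` — 57%
compound 3 `CN(Cc1ccc(C2=NCCN2)cc1)C(=O)COCCN(C)S(=O)(=O)c1c(Cl)cccc1Cl` — "not determined" (no result reported)

In an ADME assay on microsomes from liver (Homo sapiens) for metabolic stability, with a stated time of 30 min, tested at 1 uM (a higher number here means that more of the compound is left, a lower number that less of the compound is left), compound 2 gives 57%, the higher of the two numbers at hand; compound 1 sits lower by a gap beyond the usual scatter, and compound 3 has no number. Compound 4 `COc1cc(C)c(S(=O)(=O)N(C)CCOCC(=O)N2CCN(CCCN(C)C)CC2)c(C)c1` differs from compound 2 in one place: a group of 6 heavy atoms (5 carbon, 1 nitrogen; no ring) in place of a group of 8 heavy atoms (7 carbon, 1 nitrogen; 2 six-membered non-aromatic rings with 1 hetero atom each), on an amine nitrogen in a ring. Among the measured compounds shown here, no measured pair of this kind exists, so the step is only an expectation. Given that compound 1, which also carries a dimethylamino group on an open chain, gives 36%, the expected step of a number 17 percentage points lower from compound 2 to compound 4 (beyond the scatter) is downward, moderately beyond the scatter. Compound 4 is estimated at 40%, within 25% to 58%.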

Compound 4, percent of the compound remaining: 67%
The estimate for compound 4 lay 27 percentage points below the measured number, and the stated range ends below it.
By their numbers in this assay, from the lowest: compound 1; then compounds 2 and 4 (each within the scatter of the next).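

In this assay the change to 3-(dimethylamino)propyl on the amine nitrogen in the ring gives a number 10 percentage points higher from compound 2 to compound 4 (within the scatter), so this position tolerates an open chain in place of the group with two six-membered non-aromatic rings, with no difference that can be read. The stereocentre and both rings of the departing group are thus not required to hold this read-out. Nothing at hand explains this outcome. Going by these compounds, whether a shorter chain, such as 2-(dimethylamino)ethyl, or a terminal morpholine on the propyl chain would behave alike remains open.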